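The compounds below may be only part of what the source reports. "The series", "measured", "known", "first", "only" and "open" are said of these compounds alone.

Working notes on the series in an assay on isolated protein for inhibition of DNA topoisomerase 1 (Homo sapiens), with a stated time of 30 min, tested at 100 uM; a lower number here means a weaker effect, a higher number a stronger effect of the compound at the concentration tested.

Compound 1 `Cc1cccc(-c2nc3ccc(C)cc3c(=O)[nH]2)c1` gives 75.7%. Compound 2 `Cc1ccc2nc(-c3ccccc3C(F)(F)F)[nH]c(=O)c2c1` gives 72%, a number that sits within the scatter of compound 1, so no order between the two is claimed. Compound 3 `Cc1ccc2nc(-c3ccccc3C)[nH]c(=O)c2c1` gives 0%. For the measured compounds named here, the one counted step, a number 72 percentage points higher from compound 3 to compound 2 (beyond the scatter), comes with the change (trifluoromethyl in place of methyl on an aromatic carbon). Between the cores of compound 1 and compound 3 the difference is not broken down here.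

Compound 4 `Cc1ccc2nc(-c3cccc(C(F)(F)F)c3)[nH]c(=O)c2c1` differs from compound 1 by trifluoromethyl in place of methyl on an aromatic carbon. The change is the same kind as that from compound 3 to compound 2, not the same: there the group enters ortho to a large group, here meta to a large group. Since compound 1 already stands at 75.7%, little room remains upward, so the step is expected to be small, a number 4.3 percentage points higher from compound 1 to compound 4 (within the scatter). Compound 4 is estimated at 80%, between 62% and 96%.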

Compound 4, a percentage reported as inhibition, at one concentration (the size of the read-out at that concentration, not a potency): 45.8%
Estimate against measurement, compound 4: 34.2 percentage points above; measured number below the stated range.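

In this assay, trifluoromethyl in place of methyl on an aromatic carbon gives a number 29.9 percentage points lower from compound 1 to compound 4 (beyond the scatter), and this step does not match the earlier one: the same change on two cores in this assay, a number 72 percentage points higher (beyond the scatter) from compound 3 to compound 2 and a number 29.9 percentage points lower (beyond the scatter) from compound 1 to compound 4, 101.9 percentage points apart, beyond the scatter of two such steps

The change therefore cannot be carried from one core to another in this series as a fixed step, not even in its direction. Two pairs do not show what sets the direction, and the place of the change differs between them, so no rule for other cores follows.

Still open, going by these compounds, is whether a nitrile or a methoxy group in the place of the trifluoromethyl of compound 4 would give a number nearer that of compound 1. The effect of an amine or a carboxylic acid there is open too.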